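The compounds below may be only part of what the source reports. "The series", "measured", "known", "first", "only" and "open" are said of these compounds alone.

Three compounds have so far been measured in a functional assay on B16 cells (Mus musculus) for cytotoxicity, read by MTT assay, with a stated time of 72 h; on this read-out lower numbers stand for stronger inhibition and higher numbers for weaker inhibition:

Compound 1 `CN(C)CCCCOc1c(OCc2ccccc2)cc(O)c2c(=O)cc(-c3ccccc3)oc12`: 3220 nM
Compound 2 `CCN(CC)CCCCOc1c(OCc2ccccc2)cc(O)c2c(=O)cc(-c3ccccc3)oc12`: 4880 nM
Compound 3 `CN1CCN(CCCCOc2c(OCc3ccccc3)cc(O)c3c(=O)cc(-c4ccccc4)oc23)CC1`: 2370 nM

All three share the same core and the same benzyloxy group, and differ only in the amine carried on the chain. Compound 3 gives the lowest of the three numbers, but its gap from compound 1, a 1.4-fold lower number from compound 1 to compound 3 (0.13 log units; within the scatter), lies within the usual scatter, so the two cannot be ranked. Its gap from compound 2, a 2.1-fold lower number from compound 2 to compound 3 (0.31 log units; beyond the scatter), is modest yet beyond the scatter. The remaining step, a 1.5-fold higher number from compound 1 to compound 2 (0.18 log units; within the scatter), is again within the scatter.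

Compound 4 `CN1CCN(CCCCOc2c(OCc3nc4ccccc4o3)cc(O)c3c(=O)cc(-c4ccccc4)oc23)CC1` differs from compound 3 in a different part of the molecule: 1,3-benzoxazol-2-yl in place of phenyl on a saturated chain carbon bound to an oxygen on an aromatic ring. None of the three measured steps touches this part; each of them swaps one amine for another while the benzyloxy group stays fixed. Among the compounds with values here, no measured step therefore bears on the change from compound 3 to compound 4, and the numbers give no direction for it. The expectation is consequently a step of no particular size, a 1.0-fold higher number from compound 3 to compound 4 (0.01 log units; within the scatter), with a wide band of uncertainty around it. Compound 4 is estimated at 2400 nM, expected to lie between 800 nM and 7500 nM.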

Compound 4, half-maximal inhibitory concentration: 2080 nM
Estimate against measurement, compound 4: 1.2-fold (0.06 log units) above; measured number inside the range.
By their numbers in this assay, from the lowest: compounds 4, 3, 1 and 2 (each within the scatter of the next, the first and the last beyond it).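

Within the data shown here, until this point only the amine on the chain had varied, so this is the first reading of the other part of the molecule, the group on a saturated chain carbon bound to an oxygen on an aromatic ring. In this assay, 1,3-benzoxazol-2-yl in place of phenyl gives a 1.1-fold lower number from compound 3 to compound 4 (0.06 log units; within the scatter), so compound 3 and compound 4 cannot be ranked, even though the entering group has 9 heavy atoms against 6 and 2 hydrogen-bond acceptors against 0. Nothing measured here offers an explanation for this outcome.

As far as these compounds go, this is a single step with a single amine, 4-methylpiperazin-1-yl, so it remains open whether 1,3-benzoxazol-2-yl would give the same picture alongside dimethylamino or diethylamino. Also open, from the compounds shown here alone, is how the number would respond to a smaller group at this place, such as methyl, to another ring, such as pyridin-2-yl, or to a morpholin-4-yl amine or a longer chain elsewhere in the molecule.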